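A few compounds are considered here, and "the series" means these few. Any claim that something is new, unique, unknown or untested is made for them only; others in the source may bear on it.

Measured compounds in an ADME assay for inhibition of Bile salt export pump (Homo sapiens), read by scintillation counting, with a stated time of 5 min; on this read-out higher numbers stand for weaker inhibition and lower numbers for stronger inhibition:
Compound 1 `C[C@H](Oc1ccc(C(F)(F)F)cc1-c1ccc(S(C)(=O)=O)c(C(F)(F)F)c1)C(=O)O` gives 35800 nM.
Compound 2 `CN(C)C(=O)c1ccc(S(=O)(=O)c2ccc(NC(=O)[C@@](C)(O)C(F)(F)F)c(Cl)c2)cc1` gives only a limit, < 12900 nM.
Compound 3 `O=CN(O)C(CCc1ccccc1)CS(=O)(=O)N1CCN(c2ccc(Cl)cn2)CC1` gives only a limit, < 10000 nM.

Compound 2 therefore has no exact number in this assay, only a limit; of the three values shown, one sits at the limit of < 12900 nM in this assay, at which 1 of the 3 values shown sits, and another at the limit of < 10000 nM in this assay, at which 1 of the 3 values shown sits, so only compound 1 carries a measured number. Compound 4 `C[C@@](O)(C(=O)Nc1ccc(S(=O)(=O)c2ccc(NCCO)cc2)cc1Cl)C(F)(F)F` differs from compound 2 in one place: (2-hydroxyethyl)amino in place of dimethylcarbamoyl on an aromatic carbon. Within the data shown here, no pair of measured compounds shows this change, so its effect is unknown. In this assay no step beyond the scatter is expected in either direction, and the change from compound 2 to compound 4 is estimated as a step that the limit leaves unreadable from compound 2 to compound 4. Compound 4 is expected near 11000 nM, between 3500 nM and 30000 nM.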

Compound 4, half-maximal inhibitory concentration: 27400 nM
For compound 4 the middle estimate is 2.5-fold (0.40 log units) below the measured one, within the range that was stated.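

In this assay, placing (2-hydroxyethyl)amino instead of dimethylcarbamoyl on this aromatic carbon gives an at least 2.1-fold higher number from compound 2 to compound 4 (0.32 log units; beyond the scatter), so inhibition becomes weaker. Among these compounds, this is the first readable sign that the group at this position affects the result, since the earlier compounds offered no such pair. The step is only a minimum because compound 2 carries a limit: the limit of < 12900 nM in this assay, at which 1 of the 4 values shown sits.

From the compounds shown here alone, it remains open which part of (2-hydroxyethyl)amino matters. A simple amine, a carboxylic acid or a longer chain on this same carbon might shift the number differently.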